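The source may report more compounds than this note shows. Statements on the series, on what has been measured and on what is new or still open speak of the compounds shown alone.

Compound 1 (`C/N=c1\c(O)c(O)\c1=N/Cc1ccc(C#N)cc1`) has no exact potency on record in a functional assay for inhibition, with Rattus norvegicus as the target; a lower number here means a stronger inhibitor, a higher number a weaker inhibitor. In this assay compound 1 gives > 30000 nM, which is a limit of the assay and not a number. Compound 2 (`CC(C)(C)/N=c1\c(O)c(O)\c1=N/Cc1ccc(Cl)cc1`) differs from compound 1 in more than one place, and in this assay compound 2 gives a measured 1700 nM.

Compound 3 (`CC(C)(CO)/N=c1\c(O)c(O)\c1=N/Cc1ccc(C#N)cc1`) has not yet been measured. It keeps the rest of compound 1 and changes one group, with 1-(hydroxymethyl)-1-methylethyl in place of methyl on a double-bonded nitrogen.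

A move towards stronger inhibition in this assay, beyond the usual scatter, is expected. This expectation rests on compound 2 at 1700 nM, which shows that a measurable number can be reached with the shared core. That is thin support, since compound 2 is the only such case, and compound 3 could still end up at a limit. The expected change is an at least 10-fold lower number from compound 1 to compound 3 (1.00 log units; beyond the scatter). For compound 3 the estimated value is 3000 nM, with an expected range from 400 nM to 25000 nM.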

Compound 3, half-maximal inhibitory concentration: 21300 nM
For compound 3 the middle estimate is 7.1-fold (0.85 log units) below the measured one, and the stated range covers the measured number.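

With 1-(hydroxymethyl)-1-methylethyl in place of methyl on a double-bonded nitrogen, the rest of compound 1 now yields an exact number: in this assay compound 3 gives 21300 nM. The size of this change can be read only as a floor, an at least 1.4-fold lower number from compound 1 to compound 3 (0.14 log units; that floor lies within the scatter), so the data show a measurable compound at this position but do not establish a gain beyond the scatter. The reading stops at a floor because compound 1 carries a limit of the assay and not a number: the limit of > 30000 nM in this assay, at which 1 of the 3 values shown sits.

The compounds shown do not tell whether the hydroxymethyl part of the new group or its branched carbons matter more, and a tert-butyl group, an ethyl group or an amine at this place, with the rest of compound 1 kept, would begin to separate the two. Compound 2 differs from compound 3 in more than one place, so the nitrile and the chlorine on the other side of the shared core also remain unseparated, and a chlorine paired with the new group, or a nitrile paired with tert-butyl, stays an open case.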